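Heteroaryl replacing sulfonamide on the indane-imidazole core

A few compounds are considered here, and "the series" means these few. Any claim that something is new, unique, unknown or untested is made for them only; others in the source may bear on it.

Measured compounds:
Compound 1, `c1cc(-c2nccs2)c2c(c1)C(c1ncc[nH]1)CC2`: 64%
Compound 2, `CCS(=O)(=O)Nc1cccc2c1CCC2c1ncc[nH]1`: 86%

In a functional assay on CHO cells for agonist activity at Alpha-1A adrenergic receptor (Homo sapiens), read by FLIPR and calcium flux (on this read-out higher numbers stand for larger maximal responses and lower numbers for smaller maximal responses), compound 2 gives 86% and stands highest of the two numbers shown; its nearest neighbour is compound 1 with 64%. Among the compounds with values here, the single step measured so far, a number 22 percentage points higher from compound 1 to compound 2 (beyond the scatter), involved (ethylsulfonyl)amino in place of 1,3-thiazol-2-yl on an aromatic carbon. Compound 3, `Cc1oncc1-c1cccc2c1CCC2c1ncc[nH]1`, is not yet measured. It differs from compound 2 by 5-methyl-1,2-oxazol-4-yl in place of (ethylsulfonyl)amino on an aromatic carbon. This change reverses the direction of the measured step in kind: a five-membered aromatic ring with two hetero atoms again takes the place of the (ethylsulfonyl)amino group, much as 1,3-thiazol-2-yl sits in compound 1. Within the data shown here, the one step that bears on it, a number 22 percentage points higher from compound 1 to compound 2 (beyond the scatter), was beyond the scatter and modest. Compound 3 is therefore expected to fall below compound 2 by about a number 18 percentage points lower from compound 2 to compound 3 (beyond the scatter) in this assay, landing at an estimated 68% with a range from 50% to 88%.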

Compound 3, largest response reached (Emax), in percent of the reference or control that the assay uses: 63%
For compound 3 the middle estimate is 5 percentage points above the measured one; the range from low to high includes it.
By their numbers in this assay, from the lowest: compounds 3 and 1 (each within the scatter of the next); then compound 2.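

In this assay a second five-membered aromatic ring on this aromatic carbon gives the same picture as the first, with a number 1 percentage points lower from compound 1 to compound 3 (within the scatter) showing that 5-methyl-1,2-oxazol-4-yl and 1,3-thiazol-2-yl cannot be told apart here. With a number 23 percentage points lower from compound 2 to compound 3 (beyond the scatter) as a second, independent replacement, the higher response of compound 2 no longer rests on a single comparison, and (ethylsulfonyl)amino stands apart from both rings. Nothing available here accounts for this difference.

Going by these compounds, it remains open whether the response depends on the whole (ethylsulfonyl)amino group or on only part of it, which a (methylsulfonyl)amino group or a plain amine on the same carbon could test. On these data alone, it is equally open whether the methyl on the ring matters, as an unsubstituted 1,2-oxazol-4-yl would show.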